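This account rests on a few compounds, and the source may have more. Where it says the series, first, only, none or still open, it means among the compounds named here.

Compound 1 `CCOC(=O)C1=Cc2ccccc2OC1(OCc1cn(CC(=O)Nc2ccccc2Br)nn1)C(F)(F)F` — > 150000 nM
Compound 2 `CCOC(=O)C1=Cc2ccccc2OC1(OCc1cc(-c2ccc(Br)cc2)no1)C(F)(F)F` — > 150000 nM

Both values come from a functional assay on MCF7 cells (Homo sapiens) for inhibition, read by MTT assay, with a stated time of 24 h; a higher number here means a weaker inhibitor, a lower number a stronger inhibitor. For compound 1 the value > 150000 nM is a limit of the assay and not a measured number. For compound 2 the value > 150000 nM is likewise a limit and not a number. Compound 2 thus stands at the edge of what this assay can report, with no measured potency of its own; both values sit at the same point: the limit of > 150000 nM in this assay, at which 2 of the 2 values shown sit. Among the measured compounds shown here, no step between two measured compounds is available, so nothing here shows how a change on the shared core moves this number.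

Compound 3 `CCOC(=O)C1=Cc2ccccc2OC1(OCc1cc(-c2cccc(C(F)(F)F)c2)no1)C(F)(F)F` differs from compound 2 in one place: 3-(trifluoromethyl)phenyl in place of 4-bromophenyl on an aromatic carbon. For the measured compounds named here, no measured step speaks to this change, and compound 2 itself gave only a limit. The expected step from compound 2 to compound 3 is a step that the limit leaves unreadable from compound 2 to compound 3, none beyond the scatter. Compound 3 is expected to give about 200000 nM in this assay, between 60000 nM and 600000 nM, most likely again as a limit rather than a number.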

Compound 3, half-maximal inhibitory concentration: 22100 nM
Beside the measured number, compound 3's estimate is 9.0-fold (0.96 log units) above it; the whole stated range lies above it.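

In this assay, putting 3-(trifluoromethyl)phenyl in place of 4-bromophenyl on the aromatic carbon next to the ring nitrogen of the five-membered ring gives an at least 6.7-fold lower number from compound 2 to compound 3 (0.83 log units; beyond the scatter), which shows that the group at this position can bring a compound of this series from the assay's limit to a measured number. Compound 2 gives > 150000 nM, which is a limit of the assay and not a number. The size of the step is therefore only a minimum and the true gap could be wider, because the step starts from a limit rather than from a measured value: the limit of > 150000 nM in this assay, at which 2 of the 3 values shown sit.

The two groups differ both in what they carry and in where they carry it, 4-bromo against 3-trifluoromethyl, so the compounds shown cannot say whether the kind of group, its place on the phenyl ring, or both together account for the step. As far as these compounds go, it also stays open how this assay would respond to a plain phenyl, or to a phenyl carrying an amine, a carboxylic acid or a methoxy group at this position.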